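Acetyl in Place of Methyl on the Azetidine Nitrogen

The source may report more compounds than this note shows. Statements on the series, on what has been measured and on what is new or still open speak of the compounds shown alone.

Of the compounds shown here, two have been measured in an assay on lysate for inhibition of 6-phosphofructo-2-kinase/fructose-2,6-bisphosphatase 3 (Homo sapiens), with stated times of 0.5 min and 45 min; a lower number here means a stronger inhibitor, a higher number a weaker inhibitor. Compound 1 `CN(C)C(=O)c1ccncc1Nc1cc(-c2ccc3ccn(C)c3c2)c2nccnc2c1` gives > 100000 nM in this assay, which is a limit rather than a number. Compound 2 `CN1CC(NC(=O)c2ccncc2Nc2cc(-c3ccc4ccn(C)c4c3)c3nccnc3c2)C1` gives 9190 nM in this assay; this is the only number shown, the other value being (the limit of > 100000 nM in this assay, at which 1 of the 2 values shown sits). Among the compounds with values here, the single measured step, an at least 10-fold lower number from compound 1 to compound 2 (1.03 log units; beyond the scatter), is therefore only known as a limit-bounded change. Compound 3 `CC(=O)N1CC(NC(=O)c2ccncc2Nc2cc(-c3ccc4ccn(C)c4c3)c3nccnc3c2)C1` differs from compound 2 by acetyl in place of methyl on an amine nitrogen in a ring. Within the data shown here, the measured step of an at least 10-fold lower number from compound 1 to compound 2 (1.03 log units; beyond the scatter) alters the group on the carbonyl carbon rather than the substituent on the ring nitrogen, so it does not bear directly on this change, and no other step is available. Compound 3 is therefore expected to give 12000 nM, within 4000 nM to 40000 nM in this assay. The step of a 1.3-fold higher number from compound 2 to compound 3 (0.12 log units; within the scatter) is expected to lie within the scatter.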

Compound 3, half-maximal inhibitory concentration: 97400 nM
Compound 3: the middle estimate sits 8.1-fold (0.91 log units) below what was measured; measured number above the stated range.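

In this assay, within the data shown here, acetyl in place of methyl on an amine nitrogen in a ring gives an 11-fold higher number from compound 2 to compound 3 (1.03 log units; beyond the scatter), so this ring nitrogen, which stayed unchanged in the earlier compounds, is not indifferent to what it carries. The azetidine ring alone therefore does not secure the value of compound 2: with the methyl on that nitrogen the data show an at least 10-fold lower number from compound 1 to compound 2 (1.03 log units; beyond the scatter), and with the acetyl there they show an at least 1.0-fold lower number from compound 1 to compound 3 (0.01 log units; that floor lies within the scatter). The step from compound 1 to compound 3 cannot be read as a size, since compound 1 stands at a limit: the limit of > 100000 nM in this assay, at which 1 of the 3 values shown sits.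

On these data alone, what a plain hydrogen, an ethyl group or a longer chain on this ring nitrogen would give remains open. The values shown also leave open why the acetyl weakens inhibition this far.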